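Aryl-piperazine ketones: cytotoxicity on Vero cells

The compounds below may be only part of what the source reports. "The series", "measured", "known", "first", "only" and "open" are said of these compounds alone.

Compound 1 `O=C(CCN1CCN(c2ccc(F)cc2)CC1)c1ccc(F)c(Br)c1` and compound 3 `O=C(CCN1CCN(c2ccc(F)cc2)CC1)c1ccc(F)c(F)c1` share one core; the difference between them is fluoro in place of bromo on an aromatic carbon. In an ADME assay on Vero cells (Chlorocebus sabaeus) for cytotoxicity, read by resazurin assay, with a stated time of 72 h (on this read-out lower numbers stand for stronger inhibition and higher numbers for weaker inhibition), compound 1 gives 352000 nM and compound 3 gives 385000 nM, so a 1.1-fold higher number from compound 1 to compound 3 (0.04 log units; within the scatter). Compound 2 `O=C(CCN1CCN(c2ccc(C(F)(F)F)cc2)CC1)c1ccc(F)c(Br)c1` carries on compound 1 the same change that compound 4 `O=C(CCN1CCN(c2ccc(C(F)(F)F)cc2)CC1)c1ccc(F)c(F)c1` carries on compound 3, namely trifluoromethyl in place of fluoro on an aromatic carbon and (trifluoromethyl in place of fluoro on an aromatic carbon), at places that read the same word for word. In this assay compound 2 gives 66800 nM, and a 5.3-fold lower number from compound 1 to compound 2 (0.72 log units; beyond the scatter). Compound 4 has not yet been measured in this assay. Resting on the measured step of a 5.3-fold lower number from compound 1 to compound 2 (0.72 log units; beyond the scatter) and on the value of compound 3, 385000 nM, a step of a 5.1-fold lower number from compound 3 to compound 4 (0.71 log units; beyond the scatter) is expected. Compound 4 is accordingly estimated at 75000 nM, with a range from 35000 nM to 160000 nM.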

Compound 4, half-maximal inhibitory concentration: 14000 nM
For compound 4 the middle estimate is 5.4-fold (0.73 log units) above the measured one, and the stated range ends above it.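

In this assay trifluoromethyl in place of fluoro lowers the number on both cores, but the size does not carry over, and the step is larger on the core of compound 3 (a 28-fold lower number from compound 3 to compound 4 (1.44 log units; beyond the scatter)): the same change on two cores in this assay, a 5.3-fold lower number (0.72 log units; beyond the scatter) from compound 1 to compound 2 and a 28-fold lower number (1.44 log units; beyond the scatter) from compound 3 to compound 4, 5.2-fold (0.72 log units) apart, beyond the scatter of two such steps. Fluoro in place of bromo is likewise not a fixed step, since it matters only with trifluoromethyl present (a 4.8-fold lower number from compound 2 to compound 4 (0.68 log units; beyond the scatter)): the same change on two cores in this assay, a 1.1-fold higher number (0.04 log units; within the scatter) from compound 1 to compound 3 and a 4.8-fold lower number (0.68 log units; beyond the scatter) from compound 2 to compound 4, 5.2-fold (0.72 log units) apart, beyond the scatter of two such steps. These four compounds show that the two changes do not add up independently here, but they do not show why, nor how far this holds beyond this one set.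

Open, from the compounds shown here alone, is whether a chloro or methoxy group in place of trifluoromethyl would show the same dependence on the other halogen. Also open, going by these compounds, is whether it survives a longer chain.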